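Nitro in place of chloro at a second position

The source may report more compounds than this note shows. Statements on the series, on what has been measured and on what is new or still open speak of the compounds shown alone.

Three compounds sharing one core were tested in a functional assay on the whole organism (strain Wistar albino) for inhibition, with Rattus norvegicus as the target, read by paw edema, with stated times of 30 min and 2 h, at a dose of 20 mg/kg by the oral route; on this read-out lower numbers stand for less inhibition and higher numbers for more inhibition at the one dose given (going by the name of the read-out). Compound 1 `Cc1cc(=O)oc2cc(OC(=O)CNc3ccccc3[N+](=O)[O-])ccc12` gives 16.6%, compound 2 `Cc1cc(=O)oc2cc(OC(=O)CNc3ccccc3Cl)ccc12` gives 11.5%, and compound 3 `Cc1cc(=O)oc2cc(OC(=O)CNc3ccc(Cl)cc3)ccc12` gives 23%. Compound 2 and compound 3 have the same atoms joined differently, (4-chlorophenyl in place of 2-chlorophenyl on an amine nitrogen), and a number 11.5 percentage points higher from compound 2 to compound 3 (beyond the scatter). Compound 2 and compound 1 differ by nitro in place of chloro on an aromatic carbon, and a number 5.1 percentage points higher from compound 2 to compound 1 (within the scatter). Compound 4 `Cc1cc(=O)oc2cc(OC(=O)CNc3ccc([N+](=O)[O-])cc3)ccc12` is not yet measured; it differs from compound 3 by nitro in place of chloro on an aromatic carbon. This is the same kind of change as from compound 2 to compound 1 but not the same one: there the group sits ortho to a large group, here para to a large group. A similarly small step is expected here, because a number 5.1 percentage points higher from compound 2 to compound 1 (within the scatter) lay within the scatter: a number 5 percentage points higher from compound 3 to compound 4 (within the scatter). Compound 4 is therefore estimated at 28%, with a likely range from 16% to 40%.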

Compound 4, a percentage reported as inhibition, in the whole organism at one dose (the size of the read-out at that dose, not a potency): 17.9%
Beside the measured number, compound 4's estimate is 10.1 percentage points above it; the range from low to high includes it.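

In this assay, nitro in place of chloro on an aromatic carbon para to a large group gives a number 5.1 percentage points lower from compound 3 to compound 4 (within the scatter). Set beside the earlier step, the change reads the same on both cores: the same change on two cores in this assay, a number 5.1 percentage points higher (within the scatter) from compound 2 to compound 1 and a number 5.1 percentage points lower (within the scatter) from compound 3 to compound 4, 10.2 percentage points apart, within the scatter of two such steps In these two pairs, then, the swap stays within the scatter and can be carried from one core to the other without a visible difference, but two pairs at one dose set no rule for other cores and do not show that the two groups are equivalent.

Open, going by these compounds, is whether an amine or a carboxylic acid at this place would move the number beyond the scatter. Also open, on these data alone, is what a longer chain on the amine nitrogen, in place of the aromatic ring, would do.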